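A few compounds are considered here, and "the series" means these few. Any claim that something is new, unique, unknown or untested is made for them only; others in the source may bear on it.

Going by the values given here, compound 1 `COc1cc(-c2nccn3cc(-c4ccc5[nH]ccc5c4)nc23)cc(OC)c1OC` gives 74 nM in a functional assay on MDA-MB-231 cells (Homo sapiens) for inhibition, read by MTT assay, with a stated time of 48 h (on this read-out lower numbers stand for stronger inhibition and higher numbers for weaker inhibition), and stands as the only measured number in the set so far. Compound 2 `COc1cc(-c2nccn3cc(-c4ccc([N+](=O)[O-])cc4)nc23)cc(OC)c1OC` gives in this assay only > 10000 nM, which is a limit of the assay. The step between them, an at least 130-fold higher number from compound 1 to compound 2 (2.13 log units; beyond the scatter), shows how sharply the series answers an exchange of this group; the stated size of that step rests on (the limit of > 10000 nM in this assay, at which 1 of the 2 values shown sits). Compound 3 `COc1cc(-c2nccn3cc(-c4ccc(C)cc4)nc23)cc(OC)c1OC` is not yet measured. It differs from compound 1 by 4-methylphenyl in place of 1H-indol-5-yl on an aromatic carbon. Among the compounds with values here, the single measured step that bears on this change is the one from compound 1 to compound 2, which was large and carried the number out of the reach of the assay. The change toward compound 3 removes the same group but brings in a different one, so an upward step is expected in this assay, plausibly smaller than the measured one. The expected step is a 16-fold higher number from compound 1 to compound 3 (1.21 log units; beyond the scatter). Compound 3 is estimated at 1200 nM, with a range from 250 nM to 8000 nM.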

Compound 3, half-maximal inhibitory concentration: 53 nM
Compound 3: middle estimate off by 23-fold (1.35 log units), on the high side, outside the stated range (below it).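

In this assay, 4-methylphenyl in place of 1H-indol-5-yl gives a 1.4-fold lower number from compound 1 to compound 3 (0.14 log units; within the scatter), so the two compounds cannot be told apart, and this place on the core accepts either group. Compound 3 has neither the hydrogen-bond donor nor the five-membered aromatic ring of 1H-indol-5-yl, so neither feature is required for a number of this order in the compounds shown. The large step seen earlier therefore cannot be put down to the departure of 1H-indol-5-yl alone, since with the phenyl ring kept, methyl in place of nitro gives an at least 180-fold lower number from compound 2 to compound 3 (2.27 log units; beyond the scatter), a step whose stated size rests on a limit: the limit of > 10000 nM in this assay, at which 1 of the 3 values shown sits.

The compounds shown do not tell whether the nitro group is an isolated case or one end of a wider trend, since only methyl and nitro are compared on the phenyl ring. An unsubstituted phenyl, or an amine, a methoxy group or a carboxylic acid in place of the methyl of 4-methylphenyl, would show how much of this range depends on the group carried by that ring.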